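The compounds below may be only part of what the source reports. "The series", "measured", "known", "first", "only" and "open" are said of these compounds alone.

Measured so far in an ADME assay on Caco-2 cells (Homo sapiens) for permeability, in the apical to basolateral direction; a higher number here means that the compound crosses the layer faster, a lower number that the compound crosses the layer more slowly:
compound 1, `CCS(=O)(=O)N1CCC(CN(C2Cc3cc(C#N)ccc3N(Cc3cncn3C)C2)S(=O)(=O)c2ccccn2)CC1`: 0.1 10^-6 cm/s
compound 2, `Cn1cncc1CN1CC(N(CC2CCN(C(=O)c3ccco3)CC2)S(=O)(=O)c2ccccn2)Cc2cc(C#N)ccc21`: 0.5 10^-6 cm/s

Within the data shown here, compound 2 stands highest of the two numbers; its only neighbour is compound 1, and the single measured step, a 5.0-fold higher number from compound 1 to compound 2 (0.70 log units; beyond the scatter), was made at an amine nitrogen in a ring. Compound 3, `Cn1cncc1CN1CC(N(CC2CCN(C(=O)OCc3ccccc3)CC2)S(=O)(=O)c2ccccn2)Cc2cc(C#N)ccc21`, has not yet been measured in this assay. It differs from compound 2 in one place: benzyloxy in place of furan-2-yl on a carbonyl carbon. Among the measured compounds shown here, the change sits on the carbonyl carbon that the earlier step had introduced, so that step is the only guide, and it was modest. For the measured compounds named here, no measured pair shows one substituent on a carbonyl carbon swapped for another, so the direction of this change is open. The expected step is a 2.0-fold higher number from compound 2 to compound 3 (0.30 log units; within the scatter), inside or just beyond the usual scatter. The estimate for compound 3 is 1 10^-6 cm/s, within a range from 0.3 10^-6 cm/s to 3 10^-6 cm/s.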

Compound 3, apparent permeability: 1 10^-6 cm/s
Compound 3: middle estimate and measured number agree at the digits printed; the measured number falls inside the stated range.
By their numbers in this assay, from the lowest: compound 1; then compounds 2 and 3 (each within the scatter of the next).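

In this assay, benzyloxy in place of furan-2-yl on the carbonyl carbon gives a 2.0-fold higher number from compound 2 to compound 3 (0.30 log units; within the scatter), so exchanging a five-membered aromatic ring for the larger benzyloxy group, with 8 heavy atoms against 5, leaves the two numbers indistinguishable. Set against ethylsulfonyl on the amine nitrogen in a ring, benzyloxycarbonyl gives a 10-fold higher number from compound 1 to compound 3 (1.00 log units; beyond the scatter), which makes it the second carbonyl group, after (furan-2-yl)carbonyl, to stand clear of the sulfonyl compound. No supporting measurement explains either step.

From the compounds shown here alone, with only these three compounds, it remains open whether the difference from compound 1 goes with the carbonyl in general or with the aromatic rings that both carbonyl groups carry. An amine or a short alkyl chain on the carbonyl carbon, with no aromatic ring, would test this.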